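The source may report more compounds than this note shows. Statements on the series, on what has been measured and on what is new or still open speak of the compounds shown alone.

Measured so far in a functional assay on MCF7 cells (Homo sapiens) for antiproliferative activity, read by sulforhodamine B assay, with a stated time of 48 h, tested at 10 uM; on this read-out lower numbers stand for less inhibition and higher numbers for more inhibition at the one concentration tested (going by the name of the read-out):
Compound 1 `CCCCCCCCCCCCCC[C@H](O)[C@H](CO[Si](c1ccccc1)(c1ccccc1)C(C)(C)C)NC(=O)OC(C)(C)C` gives 2.79%.
Compound 2 `CCCCCCCCCCCCCC[C@H](OCOC)[C@H](CO)NC(=O)OC(C)(C)C` gives 10.2%.
Compound 3 `CCCCCCCCCCCCCC[C@H](OCOC)[C@H](CN(CC)CC)NC(=O)OC(C)(C)C` gives 25.3%.

Compound 3 stands highest of the three numbers; its nearest neighbour is compound 2, and compound 1 lies furthest below, both gaps beyond the scatter. Compound 1 and compound 2 differ in more than one place, so only their two values are compared here, not a step.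

Compound 4 `CCCCCCCCCCCCCC[C@H](OCOC)[C@H](CN1CCN(C)CC1)NC(=O)OC(C)(C)C` differs from compound 3 as follows: 4-methylpiperazin-1-yl in place of diethylamino on a saturated chain carbon, two bonds along the chain from an amide-type nitrogen.

Among the compounds with values here, the only measured step at this place is a number 15.1 percentage points higher from compound 2 to compound 3 (beyond the scatter), which swaps a hydroxy for an amine and so does not speak directly to an exchange of one amine for another. Within the data shown here, no measured pair shows what moving from diethylamino to 4-methylpiperazin-1-yl does in this assay. With nothing to anchor a shift in either direction, the expectation for compound 4 is no step beyond the scatter, so compound 4 is expected to give about 25%, within 8% to 42%. The step this estimate means is a number 0.3 percentage points lower from compound 3 to compound 4 (within the scatter), expected to be small.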

Compound 4, a percentage reported as inhibition, at one concentration (the size of the read-out at that concentration, not a potency): 28%
Compound 4: the middle estimate sits 3 percentage points below what was measured; the range from low to high includes it.
By their numbers in this assay, from the lowest: compounds 1 and 2 (each within the scatter of the next); then compounds 3 and 4 (each within the scatter of the next).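

In this assay, a second amine at this position, on a saturated chain carbon, two bonds along the chain from an amide-type nitrogen, leaves the read-out with a number 2.7 percentage points higher from compound 3 to compound 4 (within the scatter) when 4-methylpiperazin-1-yl takes the place of diethylamino. With a number 17.8 percentage points higher from compound 2 to compound 4 (beyond the scatter) alongside a number 15.1 percentage points higher from compound 2 to compound 3 (beyond the scatter) for the change from hydroxy, the gain over hydroxy is no longer tied to a single amine: it appears with both the open-chain diethylamino and the six-membered ring of 4-methylpiperazin-1-yl. No available evidence explains these values.

Still open, on these data alone, is what other groups at this position would give, such as a primary amine, morpholin-4-yl or a carboxylic acid. Also open, as far as these compounds go, is whether the gain persists with a free hydroxy in place of the methoxymethoxy group, or with a shorter chain.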